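Phenyl in Place of Phenoxy: Extending a Pair at the Limit

The source may report more compounds than this note shows. Statements on the series, on what has been measured and on what is new or still open speak of the compounds shown alone.

compound 1, `CN(C)c1ccc(NC(=O)N[C@@H]2C3CCN(CC3)[C@@H]2Cc2cccnc2)cc1`: > 10000 nM
compound 2, `O=C(Nc1ccc(Oc2ccccc2)cc1)N[C@@H]1C2CCN(CC2)[C@@H]1Cc1cccnc1`: > 10000 nM

In an assay on a protein complex for binding affinity to Neuronal acetylcholine receptor; alpha4/beta2 (Homo sapiens) (a lower number here means a stronger inhibitor, a higher number a weaker inhibitor), compound 1 reaches only the limit > 10000 nM, not a number. Compound 2 likewise gives only the limit > 10000 nM. The step that the two limits leave unreadable from compound 1 to compound 2 is therefore unreadable, as the limit of > 10000 nM in this assay, at which 2 of the 2 values shown sit, shows. Compound 3, `O=C(Nc1ccc(-c2ccccc2)cc1)N[C@@H]1C2CCN(CC2)[C@@H]1Cc1cccnc1`, differs from compound 2 by phenyl in place of phenoxy on an aromatic carbon. For the measured compounds named here, no measured step reads the effect of this change, and both neighbours sit at the limit. Compound 3 is therefore expected to stay near that limit, with an estimated step that the limit leaves unreadable from compound 2 to compound 3. The estimate for compound 3 is 15000 nM, expected between 4000 nM and 60000 nM.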

Compound 3, inhibition constant: > 10000 nM
Compound 3 gave a limit, no number; the forecaster's own chance of this, stated with the estimate: 80%; the middle value lies beyond the limit too.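

For the compounds shown here, compound 3 gives only a limit, as do compound 1 and compound 2, so no step among them can be read: the limit of > 10000 nM in this assay, at which 3 of the 3 values shown sit. The compounds shown leave open how these three rank against one another, and whether any change to the shared core yields a readable value.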